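A few compounds are considered here, and "the series" means these few. Any claim that something is new, unique, unknown or untested is made for them only; others in the source may bear on it.

Measured compounds:
- compound 1 `Cc1cc(OCc2cccc(-c3c(C)cc(OCCCS(C)(=O)=O)cc3C)c2)ccc1N(CC(=O)O)C(=O)c1ccccc1`: "not determined" (no result reported) in a physicochemical assay for lipophilicity, using the shake flask method, in phosphate buffer, measured as octanol-water partition, with a stated time of 24 h, at pH 7.4, tested at 100 uM; on this read-out lower numbers stand for lower lipophilicity and higher numbers for higher lipophilicity
- compound 2 `Cc1cc(O)cc(C)c1-c1cccc(COc2ccc(OCC(=O)O)c(F)c2)c1`: 2.37 in this assay

Of the two compounds that have been through this assay, only compound 2 came back with a number; for compound 1 no value was reported. Going by the values given here, compound 2 therefore stands alone: its reading is the only number available, and the single further entry carries no number at all. Among the compounds with values here, with just one measured value, no step between measured compounds can be drawn, and nothing yet shows how this series responds to a change in structure.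

Compound 3 `CCCOc1cc(C)c(-c2cccc(COc3ccc(OCC(=O)O)c(F)c3)c2)c(C)c1` has not yet been measured. It is related to compound 2 by one change: propyl in place of hydrogen on an oxygen on an aromatic ring. Cut one bond further out, the same difference reads hydroxy to propoxy.

Within the data shown here, since no measured step exists to lean on, the expectation rests on the structural change alone. The expected step in this assay is a number 1.23 log units higher from compound 2 to compound 3 (beyond the scatter), an upward move well beyond the usual scatter. For compound 3 the estimated value in this assay is 3.6, with an expected range from 3 to 4.2.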

Compound 3, distribution coefficient: 3.64
The estimate for compound 3 lay 0.04 log units below the measured number; low and high end bracket the measured number.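

The step gives the series its first measured reading of a structural change: in this assay, propyl in place of hydrogen on an oxygen on an aromatic ring gives a number 1.27 log units higher from compound 2 to compound 3 (beyond the scatter), a large move. Compound 1 carries no number and compound 2 had stood alone, so only now is this oxygen shown to be a place where a single change moves the read-out well beyond the usual scatter while the rest of the structure stays the same. No measurement at hand accounts for the size of this step, and one pair of compounds sets no trend.

On these data alone, what stays open is how the read-out follows the chain on this oxygen, since hydrogen and propyl are the only two substituents compared here, and a methyl group or a longer chain such as hexyl would show whether the step grows in proportion to the chain. As far as these compounds go, it is equally open how this assay would respond to an amine at the end of the propyl chain, or to the same propyl group placed elsewhere on the shared core.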